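The source may hold more compounds than are shown below. What is called first, only, known or untested is meant among the compounds shown, and "the series" means these compounds.

For the measured compounds named here, compound 2 `CC(C)CS(=O)(=O)N1C[C@@H]2[C@H](C1)[C@@]2(CNC(=O)c1ccc(Cl)cc1Cl)CC1CC1` sits at the second highest of the three numbers known in an assay on isolated protein for inhibition of sodium- and chloride-dependent glycine transporter 1 (Homo sapiens) (a lower number here means a stronger inhibitor, a higher number a weaker inhibitor), where compound 2 gives 2900 nM. Going by the values given here, compound 1 `CC(C)S(=O)(=O)N1C[C@@H]2[C@H](C1)[C@@]2(CNC(=O)c1ccc(Cl)cc1Cl)CC1CC1` is nearest, with 3400 nM, and the only one-place step known, a 1.2-fold lower number from compound 1 to compound 2 (0.07 log units; within the scatter), stays within the scatter. Among the compounds with values here, compound 3 `Cn1cnc(S(=O)(=O)N2C[C@@H]3[C@H](C2)[C@@]3(CNC(=O)c2cc(Cl)cc(Cl)c2)CC2CC2)c1`, which carries an aromatic ring on its sulfonyl sulfur but also differs elsewhere, gives 100 nM; no single step links it to compound 2. Compound 4 `O=C(NC[C@]1(CC2CC2)[C@@H]2CN(S(=O)(=O)c3cccnc3)C[C@@H]21)c1ccc(Cl)cc1Cl` differs from compound 2 by pyridin-3-yl in place of isobutyl on a sulfonyl sulfur. Within the data shown here, no measured step bears directly on an alkyl-to-aromatic change at this position, so the expectation rests mainly on the gap between compound 2 and compound 3. For compound 4, a step of a 4.8-fold lower number from compound 2 to compound 4 (0.68 log units; beyond the scatter) is expected, giving an estimate of 600 nM with a range from 150 nM to 2500 nM.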

Compound 4, half-maximal inhibitory concentration: 890 nM
Compound 4: middle estimate off by 1.5-fold (0.17 log units), on the low side; the measured number falls inside the stated range.
By their numbers in this assay, from the lowest: compound 3; then compound 4; then compounds 2 and 1 (each within the scatter of the next).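

In this assay, replacing an alkyl group on the sulfonyl sulfur with an aromatic ring can now be read directly, as one-place changes: pyridin-3-yl gives a 3.3-fold lower number from compound 2 to compound 4 (0.51 log units; beyond the scatter) and a 3.8-fold lower number from compound 1 to compound 4 (0.58 log units; beyond the scatter). Both steps lie beyond the scatter, unlike the swap between the two alkyl groups, so this position does respond to some changes. Nothing at hand accounts for this gain. A plain phenyl on the sulfonyl sulfur is not among the compounds shown, so the role of the ring nitrogen stays open. On these data alone, compound 3 differs from compound 4 in more than one place, so the source of its lower number also stays open.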